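Urea series: ring substituent swap from compound 3 to compound 4

The source may report more compounds than this note shows. Statements on the series, on what has been measured and on what is new or still open speak of the compounds shown alone.

Compound 1 `COc1cccc(NC(=O)NC2CC(C)(C)Oc3ccc(Cl)cc32)c1`, compound 2 `Cc1cccc(NC(=O)NC2CC(C)(C)Oc3ccc(Cl)cc32)c1` and compound 3 `Cc1ccc(NC(=O)NC2CC(C)(C)Oc3ccc(Cl)cc32)cc1` share one core and differ only in the aryl group on the urea nitrogen. In a functional assay (aorta) with Rattus norvegicus as the target (on this read-out lower numbers stand for an effect already at smaller amounts and higher numbers for an effect only at larger amounts of compound), compound 1 gives > 10000 nM, which is a limit of the assay and not a number. Compound 2 gives > 10000 nM in this assay, again a limit. Compound 3 gives > 30000 nM in this assay, also a limit, so compound 3 stands at no number at all; all three values of the set are limits. The steps a step that the two limits leave unreadable from compound 1 to compound 2, a step that the two limits leave unreadable from compound 1 to compound 3 and a step that the two limits leave unreadable from compound 2 to compound 3 therefore carry no size, and the only anchors are the limit of > 10000 nM in this assay, at which 2 of the 3 values shown sit, and (the limit of > 30000 nM in this assay, at which 1 of the 3 values shown sits).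

Compound 4 `CC1(C)CC(NC(=O)Nc2ccc(Cl)cc2)c2cc(Cl)ccc2O1`, not yet measured, differs from compound 3 by chloro in place of methyl on an aromatic carbon; cut one bond further out, the change reads 4-methylphenyl to 4-chlorophenyl. Among the compounds with values here, none of the measured steps gives a readable size, so no direction can be taken from them. The step from compound 3 to compound 4 is expected to be a number no higher from compound 3 to compound 4 (the limit leaves the size open), that is, no shift beyond the scatter. Compound 4 is expected to give 30000 nM in this assay, within 5000 nM to 100000 nM, most likely again reported only as a limit.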

Compound 4, half-maximal effective concentration: > 300000 nM
Compound 4: only a limit was reported; the forecaster's own chance of this, stated with the estimate: 80%; middle value at least 10-fold (1.00 log units) from the limit.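

In this assay compound 4 gives > 300000 nM, a limit of the assay and not a number. Within the data shown here, compound 1, compound 2 and compound 3 also stand only at limits, so no step to compound 4 can be read. The compounds shown leave open whether any aryl group on the urea nitrogen of this shared core gives a measurable value in this assay.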